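This account rests on a few compounds, and the source may have more. Where it says the series, first, only, none or still open, it means among the compounds named here.

Working notes on the series. In a functional assay on DLD-1 cells (Homo sapiens) for inhibition, read by MTT assay, with a stated time of 72 h (on this read-out lower numbers stand for stronger inhibition and higher numbers for weaker inhibition), compound 3 (`COc1cc(Oc2cccc(Nc3ccccc3)c2)cc(OC)c1CN[C@H](C)c1ccccc1`) gives 8570 nM. Compound 2 (`COc1cc(Oc2cccc(Nc3ccccc3)c2)cc(OC)c1CNCCNC(C)=O`) gives 6010 nM, and compound 1 (`COc1ccc(CCCNCc2c(OC)cc(Oc3ccc(Nc4ccccc4)cc3)cc2OC)cc1`) gives 4650 nM. Compound 3 lies within the scatter of both, so these numbers do not rank the three compounds.

The next compound is compound 4 (`COc1cc(Oc2cccc(Nc3ccccc3)c2)cc(OC)c1CNC1CC1`), with cyclopropyl in place of 1-phenylethyl on an amine nitrogen. The defined stereocentre of compound 3 goes with the change.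

For the measured compounds named here, only one measured step bears on this position: a 1.4-fold higher number from compound 2 to compound 3 (0.15 log units; within the scatter). That step exchanged 2-acetamidoethyl for 1-phenylethyl on the same amine nitrogen and stayed within the scatter. Going by the values given here, compound 1 differs from compound 3 in more than one place, so it offers no clean step, although compound 1 with its value of 4650 nM shows the same range of numbers. Among the compounds with values here, no measured compound yet carries a small ring on this nitrogen, so the data give no direction for the change.

A step beyond the scatter is therefore not expected in this assay. The expected size is a 1.2-fold lower number from compound 3 to compound 4 (0.09 log units; within the scatter), with no firm direction. For compound 4 the estimate is 7000 nM, expected to fall between 3000 nM and 16000 nM.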

Compound 4, half-maximal inhibitory concentration: > 20000 nM
Compound 4 was reported as a limit; the forecaster's own chance of this, stated with the estimate: 10%; at least 2.8-fold (0.45 log units) between middle value and limit.
By their numbers in this assay, from the lowest: compounds 1, 2 and 3 (each within the scatter of the next). At a limit, above all of these: compound 4.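

In this assay, the amine nitrogen now shows a change that lies beyond the scatter: cyclopropyl gives an at least 2.3-fold higher number from compound 3 to compound 4 (0.36 log units; beyond the scatter), and in place of 2-acetamidoethyl it gives an at least 3.3-fold higher number from compound 2 to compound 4 (0.52 log units; beyond the scatter). The earlier step between compound 2 and compound 3 stayed within the scatter, so the substituent on this nitrogen could have seemed open to exchange, but that holds only for 2-acetamidoethyl and 1-phenylethyl and does not extend to cyclopropyl. Compound 4 is reported only as a limit, so both steps fix a minimum size and the full size remains unknown: the limit of > 20000 nM in this assay, at which 1 of the 4 values shown sits.

The compounds shown leave open whether the drop goes with the three-membered ring itself or with the smaller count of heavy atoms, and a cyclohexyl group or an open butyl chain on the same amine nitrogen would separate these two readings. Also open, as far as these compounds go, is how the other configuration of 1-phenylethyl would read against compound 3, whose defined stereocentre is the only one in this set.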